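Swapping methyl for phenyl on a fused bicyclic core

A few compounds are considered here, and "the series" means these few. Any claim that something is new, unique, unknown or untested is made for them only; others in the source may bear on it.

Measured so far:
Compound 1 `COc1ccc(N2NC3=CC[C@@H](OC)O[C@@]3(c3ccccc3)CC2=O)cc1`: 11300 nM
Compound 2 `CO[C@@H]1CC=C2NN(c3cncnc3)C(=O)C[C@]2(C)O1`: 15100 nM

Both compounds were tested in a functional assay on HCT-116 cells (Homo sapiens) for inhibition, read by sulforhodamine B assay, with a stated time of 48 h; a higher number here means a weaker inhibitor, a lower number a stronger inhibitor. Compound 2 has the higher of the two numbers, but the gap to compound 1 lies within the usual scatter, so the two cannot be told apart on these data.

Compound 3 `CO[C@@H]1CC=C2NN(c3cncnc3)C(=O)C[C@]2(c2ccccc2)O1` has not been measured yet. It differs from compound 2 in one place: phenyl in place of methyl on a saturated ring carbon. Among the compounds with values here, no step between two measured compounds isolates this change. Compound 1 already carries a phenyl at this position, though with a different aromatic ring on the nitrogen, and compound 1 gives 11300 nM in this assay. That single comparison suggests the swap changes little. The step of a 1.5-fold lower number from compound 2 to compound 3 (0.18 log units; within the scatter) is therefore expected to stay within the scatter, leaning toward a slightly lower number. Compound 3 is estimated at 10000 nM, with a range from 4000 nM to 30000 nM.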

Compound 3, half-maximal inhibitory concentration: 9130 nM
The estimate for compound 3 lay 1.1-fold (0.04 log units) above the measured number; the measured number falls inside the stated range.
By their numbers in this assay, from the lowest: compounds 3, 1 and 2 (each within the scatter of the next).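

In this assay a direct comparison at this position now exists: phenyl in place of methyl on the saturated ring carbon gives a 1.7-fold lower number from compound 2 to compound 3 (0.22 log units; within the scatter) and so stays within the scatter, which shows that this ring carbon can carry an aromatic ring as well as a methyl with no readable difference. With that phenyl held fixed, pyrimidin-5-yl in place of 4-methoxyphenyl on the amide-type nitrogen gives a 1.2-fold lower number from compound 1 to compound 3 (0.09 log units; within the scatter) and also stays within the scatter, so neither change separates these compounds. Nothing available here explains these results.

The compounds shown do not reveal whether any group on this ring carbon can move the number beyond the scatter. On these data alone, what an amine or a carboxylic acid would do there remains open.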